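The source may hold more compounds than are shown below. What is called first, only, known or untested is meant among the compounds shown, and "the series" means these compounds.

Among the measured compounds shown here, the series rests on one shared core carrying two basic side groups, and the three measured members differ only at those side groups. Compound 1 `CCN1CCN(CCCn2cnc3c(N4CCN(CC)CC4)nc(N)nc32)CC1` carries a free amino group and a 3-(4-ethylpiperazin-1-yl)propyl chain; compound 2 `CCN1CCN(CCCn2cnc3c(N4CCN(CC)CC4)nc(NCc4ccc(OC)cc4)nc32)CC1` differs from it in that the amino group bears a 4-methoxybenzyl group. In an assay on HEK293 cells for antagonist activity at Toll-like receptor 9 (Homo sapiens), read by spectrophotometry (on this read-out lower numbers stand for stronger inhibition and higher numbers for weaker inhibition), compound 1 gives 260 nM, and compound 2 gives 200 nM. Their difference is hydrogen in place of 4-methoxybenzyl on a nitrogen on an aromatic ring, and the step it made was a 1.3-fold higher number from compound 2 to compound 1 (0.11 log units; within the scatter), so the two numbers cannot be told apart. Compound 3 `CCN1CCN(c2nc(NCc3ccc(OC)cc3)nc3c2ncn3CCCN2CCCC2)CC1` keeps the 4-methoxybenzyl group of compound 2 but differs at the chain end, a change counted as pyrrolidin-1-yl in place of 4-ethylpiperazin-1-yl on a saturated chain carbon, three bonds along the chain from an aromatic nitrogen; in this assay compound 3 gives 80 nM, and the step was a 2.5-fold lower number from compound 2 to compound 3 (0.40 log units; beyond the scatter). Compound 3 thus stands lowest of the three, beyond the scatter from both others.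

Compound 4 `CCN1CCN(c2nc(N)nc3c2ncn3CCCN2CCCC2)CC1` has not yet been measured. It stands to compound 3 as compound 1 stands to compound 2: the difference is hydrogen in place of 4-methoxybenzyl on a nitrogen on an aromatic ring, at the same place as before, so it is the same change, now on the pyrrolidine-bearing core of compound 3. Because the same change from compound 2 to compound 1 gave a 1.3-fold higher number from compound 2 to compound 1 (0.11 log units; within the scatter), the step from compound 3 to compound 4 is expected to be about a 1.3-fold higher number from compound 3 to compound 4 (0.10 log units; within the scatter), with the pyrrolidine ring untouched. Compound 4 is therefore estimated to give about 100 nM in this assay, most likely between 50 nM and 220 nM.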

Compound 4, half-maximal inhibitory concentration: 190 nM
Beside the measured number, compound 4's estimate is 1.9-fold (0.28 log units) below it, and the stated range covers the measured number.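

In this assay, exchanging (4-methoxybenzyl)amino for amino gave a 2.4-fold higher number from compound 3 to compound 4 (0.38 log units; beyond the scatter), and this step cannot be told apart from the same exchange on the other core: the same change on two cores in this assay, a 1.3-fold higher number (0.11 log units; within the scatter) from compound 2 to compound 1 and a 2.4-fold higher number (0.38 log units; beyond the scatter) from compound 3 to compound 4, 1.8-fold (0.26 log units) apart, within the scatter of two such steps. Exchanging 4-ethylpiperazin-1-yl for pyrrolidin-1-yl on the core with the free amino group gave a 1.4-fold lower number from compound 1 to compound 4 (0.14 log units; within the scatter), and this step likewise cannot be told apart from its earlier counterpart: the same change on two cores in this assay, a 2.5-fold lower number (0.40 log units; beyond the scatter) from compound 2 to compound 3 and a 1.4-fold lower number (0.14 log units; within the scatter) from compound 1 to compound 4, 1.8-fold (0.26 log units) apart, within the scatter of two such steps. Across these four compounds, then, each change carried from one core to the other with a size that agrees within the scatter, but this does not show that the steps are equal or independent of the core, as each change rests on only two steps, one within the scatter and one beyond it.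

The compounds shown leave open whether this agreement extends to other groups on the amino nitrogen, such as an unsubstituted benzyl or a methyl, or to other chain ends, such as a piperidine or a dimethylamino group. They also leave open what a longer chain would do, or a morpholine in place of the 4-ethylpiperazine that all four compounds carry on the aromatic ring.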